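Solubility in a urea series: quinolin-8-yl in place of naphthalenylmethyl

The source may hold more compounds than are shown below. What is called first, only, known or untested is meant among the compounds shown, and "the series" means these compounds.

Measured compounds
compound 1 `C[C@@H]1CN([C@@H](C)CO)C(=O)c2cccc(NC(=O)NCc3cccc4ccccc34)c2O[C@H]1CN(C)S(=O)(=O)c1ccc2c(c1)OCCO2`: 100 nM
compound 2 `C[C@@H]1CN([C@@H](C)CO)C(=O)c2cccc(NC(=O)Nc3cccc4ccncc34)c2O[C@H]1CN(C)S(=O)(=O)c1ccc2c(c1)OCCO2`: 101000 nM

Compound 1 stands lowest of the two numbers in a physicochemical assay for solubility, read by HPLC, in phosphate buffer, measured as thermodynamic solubility, with a stated time of 24 h, at pH 7.4; a lower number here means a less soluble compound, a higher number a more soluble compound; its nearest neighbour is compound 2, reached by a 1000-fold higher number from compound 1 to compound 2 (3.00 log units; beyond the scatter). The unmeasured compound 3 `C[C@@H]1CN([C@@H](C)CO)C(=O)c2cccc(NC(=O)Nc3cccc4cccnc34)c2O[C@H]1CN(C)S(=O)(=O)c1ccc2c(c1)OCCO2` differs from compound 1 by quinolin-8-yl in place of (naphthalen-1-yl)methyl on an amide-type nitrogen. Among the compounds with values here, the only step that bears on this is the one from compound 1 to compound 2, where isoquinolin-8-yl replaces the same (naphthalen-1-yl)methyl; that step was large and upward. Within the data shown here, compound 3 carries quinolin-8-yl instead of isoquinolin-8-yl, so the change is of the same kind but not identical, and only one step supports it. A large upward step is therefore expected in this assay for compound 3, estimated as a 300-fold higher number from compound 1 to compound 3 (2.48 log units; beyond the scatter), somewhat smaller than the step to compound 2 to allow for the different ring. Compound 3 is expected to give about 30000 nM, with a range of 5000 nM to 150000 nM.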

Compound 3, solubility: 1800 nM
Beside the measured number, compound 3's estimate is 17-fold (1.22 log units) above it; the measured number lies below the stated range.
By their numbers in this assay, from the lowest: compound 1; then compound 3; then compound 2.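

In this assay, quinolin-8-yl in place of (naphthalen-1-yl)methyl on the amide-type nitrogen also gives a rise beyond the scatter, with an 18-fold higher number from compound 1 to compound 3 (1.26 log units; beyond the scatter) as the step, so the upward direction no longer rests on isoquinolin-8-yl alone. The two ring groups are not interchangeable at this place: a 56-fold lower number from compound 2 to compound 3 (1.75 log units; beyond the scatter) is the step between them, also beyond the scatter, so the size of the rise depends on which of the two enters. No measurement at hand accounts for that gap.

On these data alone, both steps from compound 1 change the group and remove the methyl link together, so the share of each remains open. Plain naphthalen-1-yl and (quinolin-8-yl)methyl on the same nitrogen would separate those two changes, and the compounds shown include neither.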